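The source may report more compounds than this note shows. Statements on the series, on what has been measured and on what is new or still open speak of the compounds shown alone.

In an ADME assay on HEK293 cells (Homo sapiens) for cytotoxicity, read by MTT assay, with a stated time of 48 h (a higher number here means a weaker inhibitor, a lower number a stronger inhibitor), compound 1 (`Cn1c(N)c(-c2nc3ccccc3[nH]2)c2nc(C#N)c(C#N)nc21`) gives > 50000 nM, which is a limit of the assay and not a number. Compound 3 (`CN(C)CCCCn1c(-c2c(N)n(C)c3nc(C#N)c(C#N)nc23)nc2ccccc21`) carries 4-(dimethylamino)butyl in place of hydrogen on an aromatic nitrogen of the five-membered aromatic ring with 2 nitrogen (4-(dimethylamino)butyl in place of hydrogen on an aromatic nitrogen). For the measured compounds named here, only one measured step bears on this change, and only indirectly. Compound 2 (`N#Cc1nc2c(-c3nc4ccccc4[nH]3)c(N)n(CCN3CCCC3)c2nc1C#N`) reads 18300 nM and carries (pyrrolidin-1-yl)methyl in place of hydrogen on a saturated chain carbon bound to an aromatic nitrogen. That change gives an at least 2.7-fold lower number from compound 1 to compound 2 (0.43 log units; beyond the scatter). On these data alone, its true size stays open because of the limit of > 50000 nM in this assay, at which 1 of the 2 values shown sits. It also sits at a different place on the core, so it transfers only loosely to compound 3. A step of similar size towards a lower number is still the working expectation, with a real chance that the reading stays at the limit. The estimated change is an at least 3.1-fold lower number from compound 1 to compound 3 (0.49 log units; beyond the scatter). For compound 3 the expected value is 16000 nM, with an estimated range of 5000 nM to 50000 nM.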

Compound 3, half-maximal inhibitory concentration: 7130 nM
For compound 3 the middle estimate is 2.2-fold (0.35 log units) above the measured one, and the stated range covers the measured number.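

In this assay, 4-(dimethylamino)butyl in place of hydrogen on an aromatic nitrogen of the five-membered aromatic ring gives an at least 7.0-fold lower number from compound 1 to compound 3 (0.84 log units; beyond the scatter). This position, left unchanged in compound 2, therefore also responds to substitution, and compound 3 gives a measured reading where compound 1 stands at a limit of the assay and not a number. The step has only a lower bound, and its true size stays open, because of that limit on compound 1: the limit of > 50000 nM in this assay, at which 1 of the 3 values shown sits.

The compounds shown do not separate the contribution of the terminal dimethylamino group from that of the four-carbon chain, so a plain methyl, a shorter or longer chain with the same amine, or a butyl chain ending in a hydroxyl or a carboxylic acid on this nitrogen would be the informative comparisons. Also open, on these data alone, is whether this change and the change carried by compound 2, with its pyrrolidine-bearing chain, would add up when combined on the shared core.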